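Notes on compound 2 and its side-chain exchange

The compounds below may be only part of what the source reports. "The series", "measured", "known", "first", "only" and "open" are said of these compounds alone.

Values in a functional assay on MCF7 cells (Homo sapiens) for inhibition, read by fluorescence, with a stated time of 72 h (on this read-out higher numbers stand for weaker inhibition and lower numbers for stronger inhibition), so far
- compound 1 (`Cn1cnc2c(NC(=N)N)ncnc21`) gives > 100000 nM as a limit
- compound 2 (`CC(C)n1cnc2c(NC(=N)N)nc(NCCO)nc21`) gives 12400 nM as a number
- compound 3 (`CC(C)[C@@H](N)COc1nc(NC(=N)N)c2ncn(C(C)C)c2n1`) has no value yet

Going by the values given here, compound 2 holds the only exact number (12400 nM) in this assay so far. Compound 1 gives > 100000 nM and this is a limit, not a number.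

Compound 3 carries 2-amino-3-methylbutoxy in place of (2-hydroxyethyl)amino on an aromatic carbon. The exchange sits on a six-membered aromatic ring with 2 nitrogen, between two ring nitrogen atoms, and the rest of compound 2 stays unchanged.

Among the compounds with values here, no measured pair isolates this exchange, so any expectation is loose. A moderate step towards stronger inhibition is expected, and a result within the usual scatter of compound 2 would not be surprising. The expected change is a 2.5-fold lower number from compound 2 to compound 3 (0.39 log units; beyond the scatter) in this assay on this estimate. The estimate for compound 3 is 5000 nM with an expected span from 1200 nM to 22000 nM as the range.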

Compound 3, half-maximal inhibitory concentration: 79400 nM
Compound 3: middle estimate off by 16-fold (1.20 log units), on the low side; the whole stated range lies below it.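

In this assay, 2-amino-3-methylbutoxy in place of (2-hydroxyethyl)amino on the aromatic carbon between two ring nitrogen atoms gives a 6.4-fold higher number from compound 2 to compound 3 (0.81 log units; beyond the scatter), a step towards weaker inhibition. Going by these compounds alone, this is the first readable step, and it shows that the read-out at this position responds to the side chain, with (2-hydroxyethyl)amino in compound 2 the stronger of the two groups compared. The weak end of the series is marked by compound 1, whose value is a limit and not a number: the limit of > 100000 nM in this assay, at which 1 of the 3 values shown sits.

The exchange alters several features at once, including the atom joining the chain to the ring, the chain length and branching, the terminal hydroxyl against an amine, and the presence of a defined stereocentre, so the compounds shown leave open which of these accounts for the step. A 2-hydroxyethoxy chain, a 2-aminoethylamino chain or the opposite stereoisomer of 2-amino-3-methylbutoxy would each separate one of these features from the others on the otherwise unchanged structure of compound 2.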